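The compounds below may be only part of what the source reports. "The series", "measured", "known", "first", "only" and "open" are said of these compounds alone.

Measured so far:
compound 1, `CCCCCCCCCCCC(=O)OC[C@H](CSC[C@@H](N)C(=O)N[C@@H](C)CO)OC(=O)CCCCCCCCCCC`, gives 1560 nM;
compound 2, `CCCCCCCCCCCC(=O)OC[C@H](CSC[C@@H](N)C(=O)N[C@H](C)CO)OC(=O)CCCCCCCCCCC`, gives 22200 nM;
compound 3, `CCCCCCCCCCCC(=O)OC[C@H](CSC[C@@H](N)C(=O)NC(C)CCC(C)C)OC(=O)CCCCCCCCCCC`, gives 190 nM.

All three were tested in an assay on HEK293 cells for agonist activity at Toll-like receptor 2 (Homo sapiens); on this read-out lower numbers stand for an effect already at smaller amounts and higher numbers for an effect only at larger amounts of compound. Among the three numbers, compound 1 stands second highest: compound 3 lies below it, and compound 2 above it. The three share the same core with two long ester chains and differ only at the amide end. Compounds 1 and 2 show how sensitive that end is, since a 14-fold higher number from compound 1 to compound 2 (1.15 log units; beyond the scatter) rests on the fact that compounds 1 and 2 differ only in the configuration as drawn alone. Replacing the 1-(hydroxymethyl)ethyl group by 1,4-dimethylpentyl gives an 8.2-fold lower number from compound 1 to compound 3 (0.91 log units; beyond the scatter), and from compound 2 the same replacement gives a 120-fold lower number from compound 2 to compound 3 (2.07 log units; beyond the scatter).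

Compound 4, `CCCCCCCCCCCC(=O)OC[C@H](CSC[C@@H](N)C(=O)NCCCn1ccnc1)OC(=O)CCCCCCCCCCC`, has not yet been measured. Relative to compound 1 it carries 3-(1H-imidazol-1-yl)propyl in place of 1-(hydroxymethyl)ethyl on an amide-type nitrogen. The most relevant precedent is the step from compound 1 to compound 3, where swapping the same group away lowered the number modestly. The new group is different in kind from 1,4-dimethylpentyl, so that step is only a rough guide. A modest move toward a lower number is expected, about a 2.6-fold lower number from compound 1 to compound 4 (0.41 log units; beyond the scatter), so compound 4 is estimated to give 600 nM in this assay, with a plausible range from 120 nM to 3000 nM.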

Compound 4, half-maximal effective concentration: 410 nM
Compound 4: middle estimate off by 1.5-fold (0.17 log units), on the high side, and the stated range covers the measured number.
By their numbers in this assay, from the lowest: compound 3; then compound 4; then compound 1; then compound 2.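

Losing the 1-(hydroxymethyl)ethyl group does not cost activity at this amide-type nitrogen, even when 3-(1H-imidazol-1-yl)propyl, with its five-membered aromatic ring and 0 hydrogen-bond donors, takes its place: the change gives a 3.8-fold lower number from compound 1 to compound 4 (0.58 log units; beyond the scatter) and, against the other configuration, a 54-fold lower number from compound 2 to compound 4 (1.73 log units; beyond the scatter) as well. Set against the open-chain 1,4-dimethylpentyl, the same group gives a 2.2-fold higher number from compound 3 to compound 4 (0.33 log units; beyond the scatter) and so leaves compound 3 with the lowest number of the four, yet it shows that this position can carry a ring with two hetero atoms and not only a branched carbon chain. The entering group of compound 4 has no defined stereocentre, so a low number here does not depend on the stereocentre whose configuration separates compound 1 and compound 2.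

The compounds shown cannot separate the part played by the ring from that of the propyl link, and no measured property accounts for these steps. On these data alone, how a carboxylic acid, or a longer chain ending in the same imidazole ring, would behave at this nitrogen remains open.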